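The source may hold more compounds than are shown below. What is called first, only, known or untested is meant among the compounds shown, and "the series" means these compounds.

Compound 1 `Cc1cc(O)c(C(=O)/C=C/c2ccc(F)cc2)c(-c2ccccc2)c1C(=O)/C=C/c1ccc(F)cc1` and compound 2 `COc1ccc(/C=C/C(=O)c2c(C)cc(O)c(C(=O)/C=C/c3ccc(OC)c(OC)c3)c2-c2ccccc2)cc1OC` share one core and differ in the substituents on the two cinnamoyl arms. Among the measured compounds shown here, in a functional assay on MCF7 cells (Homo sapiens) for cytotoxicity, read by MTT assay, with a stated time of 24 h (on this read-out lower numbers stand for stronger inhibition and higher numbers for weaker inhibition), compound 1 gives 20000 nM, and this is the only value in the set that comes with a number. Compound 2 in this assay gives "not active" (no number reported), so no number is available for it and nothing can be said about the size of the gap between the two. Compound 1 therefore stands alone as the reference point, and it is a weak inhibitor.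

Compound 3 `Cc1cc(O)c(C(=O)/C=C/c2ccc(F)cc2)c(-c2ccc(OCc3ccccc3)cc2)c1C(=O)/C=C/c1ccc(F)cc1` keeps the two fluorinated arms of compound 1 and changes only the pendant phenyl ring: benzyloxy in place of hydrogen on an aromatic carbon. For the measured compounds named here, no pair of measured compounds shows what such a change does here. Given that compound 1 sits at 20000 nM, the step of a 1.3-fold lower number from compound 1 to compound 3 (0.12 log units; within the scatter) is expected to be small, most likely within the usual scatter, with a modest lean toward stronger inhibition. Compound 3 is estimated to give 15000 nM, with a plausible range from 5000 nM to 50000 nM.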

Compound 3, half-maximal inhibitory concentration: 28000 nM
For compound 3 the middle estimate is 1.9-fold (0.27 log units) below the measured one; the range from low to high includes it.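

In this assay, placing benzyloxy in place of hydrogen on an aromatic carbon of the pendant phenyl ring, para to a large group, gives a 1.4-fold higher number from compound 1 to compound 3 (0.15 log units; within the scatter) and so leaves the two compounds indistinguishable on this read-out. Among the compounds shown here, this is the first reading at this position, and it shows that a group of this size, which brings a further six-membered aromatic ring, does not move the value beyond the usual scatter when the two fluorinated arms stay in place. Nothing available here accounts for this result.

The compounds shown leave open whether a small group such as methoxy, or an amine or a carboxylic acid, on the same aromatic carbon would give a value that can be told apart from that of compound 1. They also leave open whether benzyloxy would behave in the same way with the arms of compound 2, which gives no number in this assay and so offers no starting value for such a comparison.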